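The compounds below may be only part of what the source reports. "The series", "measured", "known", "first", "only" and "open" are said of these compounds alone.

Compound 1 `CC(C)=CCC[C@]1(C)/C=C/[C@@H](OC(=O)C=C(C)C)[C@](C)(O)/C=C/C(=O)/C(CN2CCN(C)CC2)=C\C1` is the reference point here. In a functional assay on SMMC-7721 cells (Homo sapiens) for antiproliferative activity, read by MTT assay, with a stated time of 48 h (a higher number here means a weaker inhibitor, a lower number a stronger inhibitor), compound 1 gives 2940 nM, the highest number among the three measured compounds. Compound 2 `CC(C)=CCC[C@]1(C)/C=C/[C@@H](OC(=O)C=C(C)C)[C@](C)(O)/C=C/C(=O)/C(COC(=O)c2ccc([N+](=O)[O-])cc2)=C\C1` gives 2560 nM in this assay, and the step of a 1.1-fold lower number from compound 1 to compound 2 (0.06 log units; within the scatter) changes nothing that can be told from the scatter. Compound 3 `CC(C)=CCC[C@]1(C)/C=C/[C@@H](OC(=O)C=C(C)C)[C@](C)(O)/C=C/C(O)/C(C=O)=C\C1` is changed at several places relative to the reference; in this assay compound 3 gives 730 nM. Going by the values given here, its number lies well below that of compound 1, but no single step connects the two, so the comparison says nothing about any one change.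

Compound 4 `CC(C)=CCC[C@]1(C)/C=C/[C@@H](OC(=O)C=C(C)C)[C@](C)(O)/C=C/C(=O)/C(C(=O)N(C(C)C)C(C)C)=C\C1` has not yet been measured. It differs from compound 1 by diisopropylcarbamoyl in place of (4-methylpiperazin-1-yl)methyl on a double-bonded ring carbon. Among the compounds with values here, only one measured step touches the same place in the core: a 1.1-fold lower number from compound 1 to compound 2 (0.06 log units; within the scatter) swapped the group on that carbon and left the number within the scatter. Within the data shown here, with that as the sole guide, a step no larger than the scatter is expected a 1.2-fold lower number from compound 1 to compound 4 (0.07 log units; within the scatter). For compound 4 in this assay a number near 2500 nM is therefore expected, with a likely range from 1000 nM to 6500 nM.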

Compound 4, half-maximal inhibitory concentration: 17200 nM
Compound 4: middle estimate off by 6.9-fold (0.84 log units), on the low side, and the stated range ends below it.
By their numbers in this assay, from the lowest: compound 3; then compounds 2 and 1 (each within the scatter of the next); then compound 4.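

In this assay, the group on this double-bonded ring carbon proves able to shift the number: with diisopropylcarbamoyl in place of (4-methylpiperazin-1-yl)methyl, the result is a 5.9-fold higher number from compound 1 to compound 4 (0.77 log units; beyond the scatter), whereas the earlier step at this carbon stayed within the scatter. Unlike compounds 1 and 2, which both keep a saturated chain carbon on the ring, compound 4 carries its carbonyl directly on the ring carbon and has no ring in the entering group, so this position does not tolerate every replacement alike. Nothing available explains the rise.

The step changes the link to the ring and the groups on the nitrogen at once, so the compounds shown cannot separate the two. As far as these compounds go, whether a diisopropylaminomethyl group, a dimethylcarbamoyl group or a carboxylic acid on this carbon would behave like compound 4 remains open.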